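Swapping trifluoromethyl for chloro on the terminal aryl

The source may hold more compounds than are shown below. What is called first, only, known or untested is meant among the compounds shown, and "the series" means these compounds.

Among the compounds with values here, compound 2, with the structure `COc1cc2cc(Oc3ccc(NC(=O)Nc4ccc(Cl)c(C(F)(F)F)c4)cc3)c(C)nc2cc1OC`, is the only compound of this pair with a measured number: in a functional assay on 786-0 cells (Homo sapiens) for inhibition, read by sulforhodamine B assay, with a stated time of 48 h (a higher number here means that more compound is tolerated, a lower number that less compound is tolerated), compound 2 gives 18800 nM. Compound 1, with the structure `COc1cc2cc(Oc3ccc(NC(=O)Nc4cccc(C(F)(F)F)c4)cc3)c(C)nc2cc1OC`, differs from it only by a hydrogen where compound 2 carries chloro. In this assay compound 1 reaches only the limit > 50000 nM, which is a limit of the assay and not a number. Within the data shown here, the step of an at least 2.6-fold lower number from compound 1 to compound 2 (0.42 log units; beyond the scatter) is the single measured step here, and it rests on the limit described by the limit of > 50000 nM in this assay, at which 1 of the 2 values shown sits. Compound 3, with the structure `COc1cc2cc(Oc3ccc(NC(=O)Nc4ccc(Cl)c(Cl)c4)cc3)c(C)nc2cc1OC`, differs from compound 2 by chloro in place of trifluoromethyl on an aromatic carbon. Among the measured compounds shown here, no measured step covers this exchange of trifluoromethyl for chloro; the only measured step concerns the neighbouring chloro group, which compound 3 keeps. Without direct evidence, the step from compound 2 to compound 3 in this assay is expected to stay within the scatter, so compound 3 is expected to give 25000 nM, between 8000 nM and 80000 nM, which means an expected step of a 1.3-fold higher number from compound 2 to compound 3 (0.12 log units; within the scatter).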

Compound 3, concentration lethal to 50% of the cells: 65200 nM
Estimate against measurement, compound 3: 2.6-fold (0.42 log units) below; measured number inside the range.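

In this assay, within the data shown here, the trifluoromethyl group of compound 2 proves not to be interchangeable with chloro, a point the earlier compounds could not show because their only step concerned the neighbouring chloro group: the exchange gives a 3.5-fold higher number from compound 2 to compound 3 (0.54 log units; beyond the scatter). The chloro group that lowered the number on going to compound 2 is still present in compound 3, so in these compounds that chloro group alone does not set the number, and the group it sits with on the terminal aryl counts as well; of the three compounds, compound 2 has the lowest number, with the steps to both others printed as beyond the scatter. Compound 1 stands at a limit and not at a number, so its comparison with compound 3, which changes the terminal aryl from 3-(trifluoromethyl)phenyl to 3,4-dichlorophenyl, cannot be read: the limit of > 50000 nM in this assay, at which 1 of the 3 values shown sits.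

The compounds shown leave open what a nitrile, a bromo group or an amine would give in place of the trifluoromethyl group of compound 2. They also leave open whether the step seen here carries over to a terminal aryl without the chloro group, since compound 1 offers only a limit as its reference.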